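Tert-Butyl in Place of Trifluoromethyl: An Estimate

The source may report more compounds than this note shows. Statements on the series, on what has been measured and on what is new or still open speak of the compounds shown alone.

compound 1 `Cc1c(C(=O)Nc2ccc(Oc3ncnc4[nH]cc(-c5ccccc5)c34)c(F)c2)c(=O)c2cc(C(F)(F)F)ccc2n1C`: 150 nM
compound 2 `CCc1ccc2c(c1)c(=O)c(C(=O)Nc1ccc(Oc3ccnc(N)c3)c(F)c1)c(C)n2C`: 888 nM

Within the data shown here, in an assay on isolated protein for inhibition of tyrosine-protein kinase receptor UFO (Homo sapiens), read by FRET and Z'-LYTE, with a stated time of 1.5 h (a lower number here means a stronger inhibitor, a higher number a weaker inhibitor), compound 1 gives 150 nM, the lowest of the two numbers measured so far. Compound 2 gives 888 nM, a gap beyond the usual scatter. Compound 3 `Cc1c(C(=O)Nc2ccc(Oc3ncnc4[nH]cc(-c5ccccc5)c34)c(F)c2)c(=O)c2cc(C(C)(C)C)ccc2n1C` differs from compound 1 by tert-butyl in place of trifluoromethyl on an aromatic carbon. Among the measured compounds shown here, no pair of measured compounds differs in this way alone, so nothing measured here tells the direction of the change. For compound 3 the expected step of a 1.7-fold higher number from compound 1 to compound 3 (0.22 log units; within the scatter) lies within the scatter or slightly toward a higher number. The estimate for compound 3 is 250 nM, from 80 nM to 800 nM.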

Compound 3, half-maximal inhibitory concentration: 42 nM
Compound 3: middle estimate off by 6.0-fold (0.77 log units), on the high side; the whole stated range lies above it.
By their numbers in this assay, from the lowest: compound 3; then compound 1; then compound 2.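

In this assay, tert-butyl in place of trifluoromethyl on this aromatic carbon gives a 3.6-fold lower number from compound 1 to compound 3 (0.55 log units; beyond the scatter), so the position accepts the larger carbon group without loss. Among these compounds, this is the first measured step at this position, and it gives the direction of the change for this one pair on the core of compound 1. Nothing measured on the compounds explains the step.

Going by these compounds, whether the same change would give the same direction on another core remains open. So does how an amine or a carboxylic acid on this carbon would compare with tert-butyl.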